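The compounds below may be only part of what the source reports. "The series", "measured", "known", "first", "only" and "open" are said of these compounds alone.

In a functional assay on MGC-803 cells (Homo sapiens) for antiproliferative activity, read by MTT assay, with a stated time of 72 h (on this read-out higher numbers stand for weaker inhibition and lower numbers for stronger inhibition), compound 3 `CC(C)c1ccc(/C=C/C(=O)c2ccc(OCC(=O)N[C@H]3CCOC3=O)cc2)cc1` gives 16800 nM, and compound 1 `O=C(COc1ccc(C(=O)/C=C/c2cccc(Cl)c2)cc1)N[C@H]1CCOC1=O` sits within the scatter of it at 29100 nM, these being the only two numbers shown. Compound 2 `O=C(COc1ccc(C(=O)/C=C/c2ccc(F)cc2)cc1)N[C@H]1CCOC1=O` reaches only the limit of the assay, > 64000 nM (the limit of > 64000 nM in this assay, at which 1 of the 3 values shown sits). Compound 4 `O=C(COc1ccc(C(=O)/C=C/c2cccc(F)c2)cc1)N[C@H]1CCOC1=O` is not yet measured; the change from compound 3 is 3-fluorophenyl in place of 4-isopropylphenyl on a double-bonded chain carbon bound to a double-bonded chain carbon. Bearing on it are a 1.7-fold lower number from compound 1 to compound 3 (0.24 log units; within the scatter) and an at least 3.8-fold lower number from compound 2 to compound 3 (0.58 log units; beyond the scatter), both running from a halogen-bearing phenyl toward the isopropyl one, while an at least 2.1-fold higher number from compound 1 to compound 2 (0.34 log units; beyond the scatter) runs into the limit. Going back from isopropyl to a fluorophenyl is therefore expected to raise the number, a 2.4-fold higher number from compound 3 to compound 4 (0.38 log units; beyond the scatter), with some chance of a limit again. Compound 4 is estimated at 40000 nM, within 18000 nM to 90000 nM.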

Compound 4, half-maximal inhibitory concentration: > 64000 nM
Compound 4 ended at the assay's limit; the forecaster's own chance of this, stated with the estimate: 30%; at least 1.6-fold (0.20 log units) between middle value and limit.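

Compound 4 gives a limit and not a number, as compound 2 does: the limit of > 64000 nM in this assay, at which 2 of the 4 values shown sit.

3-Fluorophenyl in place of 4-isopropylphenyl gives an at least 3.8-fold higher number from compound 3 to compound 4 (0.58 log units; beyond the scatter), and fluoro in place of chloro on an aromatic carbon gives an at least 2.1-fold higher number from compound 1 to compound 4 (0.34 log units; beyond the scatter); at this position, only the 3-chlorophenyl and 4-isopropylphenyl compounds give readable numbers. The step between the two fluorophenyl compounds cannot be read, leaving the effect of moving the fluoro unknown.

Still open, on these data alone, is whether a 4-chlorophenyl, a 3-isopropylphenyl or a phenyl bearing an amine would give a readable number. Also open, as far as these compounds go, is whether chloro or isopropyl matters more, as compound 1 and compound 3 lie within the scatter of each other.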